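A sulfonyl swap on an inactive cytotoxicity series

The compounds below may be only part of what the source reports. "The series", "measured", "known", "first", "only" and "open" are said of these compounds alone.

Compound 1, `CC1CCN(C2CCN(S(=O)(=O)c3cccc(N)c3)CC2)CC1`, reaches only a limit in an ADME assay on HCT-116 cells (Homo sapiens) for cytotoxicity, read by CellTiter-Glo, with a stated time of 72 h (a lower number here means a stronger inhibitor, a higher number a weaker inhibitor), giving > 5000 nM. Compound 2, `CC1CCN(C2CCN(S(=O)(=O)c3cccc(-c4ccc5ccccc5c4)c3)CC2)CC1`, likewise gives a limit of > 5000 nM. Compound 3, `CC1CCN(C2CCN(S(=O)(=O)c3cccc(-c4ccc(Cl)cc4)c3)CC2)CC1`, also gives a limit of > 5000 nM. Hence a step that the two limits leave unreadable from compound 1 to compound 2, a step that the two limits leave unreadable from compound 1 to compound 3 and a step that the two limits leave unreadable from compound 2 to compound 3 cannot be sized, because of the limit of > 5000 nM in this assay, at which 3 of the 3 values shown sit. Compound 4, `CC1CCN(C2CCN(S(=O)(=O)c3cn(C)cn3)CC2)CC1`, differs from compound 1 by 1-methyl-1H-imidazol-4-yl in place of 3-aminophenyl on a sulfonyl sulfur. Among the compounds with values here, none of the measured steps reaches this sulfonyl position, and none carries a readable size. Compound 4 is therefore expected to remain at the limit, with an expected step that the limit leaves unreadable from compound 1 to compound 4. The estimate for compound 4 is 10000 nM, spanning 4000 nM to 40000 nM.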

Compound 4, half-maximal inhibitory concentration: > 10000 nM
Compound 4 ended at the assay's limit; the forecaster's own chance of this, stated with the estimate: 85%; the middle value sits exactly at the limit.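

Compound 4 gives only a limit, > 10000 nM, and with compound 1 also at a limit, the step between them cannot be read. The compounds shown leave open whether any change on the sulfonyl sulfur gives a measurable value in this assay.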